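Replacing the 4-methylphenyl group of compound 2

The compounds below may be only part of what the source reports. "The series", "measured", "known", "first", "only" and "open" are said of these compounds alone.

In an ADME assay on the whole organism for metabolic stability, with Rattus norvegicus as the target (on this read-out lower numbers stand for a shorter-lived compound and higher numbers for a longer-lived compound), compound 2 (`Cc1ccc(S(=O)(=O)c2cc(F)c(O)c3ncccc23)cc1`) gives 0.26 h and is the lower of the two measured compounds, while compound 1 (`O=S(=O)(c1ccc(C(F)(F)F)cc1)c1cc(F)c(O)c2ncccc12`) gives 3.5 h here. Compound 3 (`O=S(=O)(c1cc(F)c(O)c2ncccc12)N1CCCC1`) has pyrrolidin-1-yl in place of 4-methylphenyl on a sulfonyl sulfur. Among the measured compounds shown here, the only measured step is large and beyond the scatter, a 13-fold lower number from compound 1 to compound 2 (1.13 log units; beyond the scatter) with methyl in place of trifluoromethyl on an aromatic carbon. For the measured compounds named here, no measured step replaces the whole group, so it bears only indirectly. A moderate rise is expected, a 3.1-fold higher number from compound 2 to compound 3 (0.49 log units; beyond the scatter) with wide uncertainty. For compound 3 a value of 0.8 h is estimated, with 0.2 h and 3.2 h as the expected ends of its range.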

Compound 3, half-life: 2.8 h
Estimate against measurement, compound 3: 3.5-fold (0.54 log units) below; the measured number falls inside the stated range.
By their numbers in this assay, from the lowest: compound 2; then compounds 3 and 1 (each within the scatter of the next).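

In this assay, the place on the sulfonyl sulfur tolerates replacement of the whole group, with an 11-fold higher number from compound 2 to compound 3 (1.03 log units; beyond the scatter) when pyrrolidin-1-yl enters for 4-methylphenyl. The earlier step changed only a substituent on the aromatic ring, whereas this one removes that ring, so in this pair the longer half-life does not require an aromatic ring at this place. Nothing measured here accounts for the rise. As far as these compounds go, it remains open whether the rise is particular to pyrrolidin-1-yl. A piperidine, a morpholine or an open-chain dimethylamino group on the same sulfur would test that.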